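The source may report more compounds than this note shows. Statements on the series, on what has been measured and on what is new or still open speak of the compounds shown alone.

Measured compounds in an assay on HEK293 cells for binding affinity to prostaglandin E2 receptor EP4 subtype (Rattus norvegicus); on this read-out higher numbers stand for weaker inhibition and lower numbers for stronger inhibition: compound 1 `O=C(O)CCCCCCN1C(=O)CC[C@@H]1CCC(O)Cc1ccccc1` with 54 nM; compound 2 `O=C(O)c1ccc(CCCN2C(=O)CC[C@@H]2CCC(O)Cc2ccccc2)s1` with 21 nM. Compound 3 `O=C(O)CCCCCCN1C(=O)CCC1CCC(O)CCc1ccccc1` is the third measured compound, and its result is taken up in its own sentence below.

Among the measured compounds shown here, compound 3 sits at the limit of this assay, > 3200 nM, and is the one compound of the three for which no number is known (the limit of > 3200 nM in this assay, at which 1 of the 3 values shown sits). Compound 1 and compound 2 both give numbers well inside the measured range, and the change from compound 1 to compound 2, 5-carboxythiophen-2-yl in place of 3-carboxypropyl on a saturated chain carbon three bonds along the chain from the amide-type nitrogen in the ring, gives a 2.6-fold lower number from compound 1 to compound 2 (0.41 log units; beyond the scatter).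

Compound 4 `O=C(O)CCCCCCN1C(=O)CC[C@@H]1CC[C@@H](O)CCc1ccccc1` is yet to be measured in this assay. It differs from compound 3 as follows: the two compounds have the same atoms and bonds; at least one stereo element is drawn with a configuration in one of them and without one in the other: 2 of 2 stereo elements differ; a stereocentre at a saturated ring carbon is drawn without a configuration in compound 3 and S in compound 4; a stereocentre at a saturated chain carbon is drawn without a configuration in compound 3 and S in compound 4. For the measured compounds named here, none of the measured steps concerns a change of drawn configuration alone, so no measured step bears on this one directly. Since compound 3 gives only a limit, any estimate for compound 4 rests on that limit and on the values of compound 1 and compound 2 for cores drawn with the ring configuration fixed. Compound 4 is expected to give 1500 nM, within 300 nM to 6000 nM, which would mean an expected step of an at least 2.1-fold lower number from compound 3 to compound 4 (0.32 log units; beyond the scatter).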

Compound 4, half-maximal inhibitory concentration: 2710 nM
Estimate against measurement, compound 4: 1.8-fold (0.26 log units) below, within the range that was stated.
By their numbers in this assay, from the lowest: compound 2; then compound 1; then compound 4. At a limit, above all of these: compound 3.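

In this assay, the compound drawn with both stereocentres as S gives a number where the drawing without configurations gave only a limit, and the change reads as an at least 1.1-fold lower number from compound 3 to compound 4 (0.07 log units; that floor lies within the scatter). Going by these compounds, this is a floor and not a size, and how far the two compounds really lie apart stays unknown because one side of the step is not a number: the limit of > 3200 nM in this assay, at which 1 of the 4 values shown sits.
Nor does the step isolate the effect of any single configuration, because the comparison sets defined stereocentres against undefined ones: the fact that one of compounds 3 and 4 is drawn with a defined configuration and the other without, at the place where they differ.

The compounds shown leave open how the R configuration at the saturated chain carbon would compare with the S configuration of compound 4. They also leave open whether a ketone in place of the chain hydroxyl, or the 5-carboxythiophen-2-yl group of compound 2 on the core of compound 4, would shift the value.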